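A few compounds are considered here, and "the series" means these few. Any claim that something is new, unique, unknown or untested is made for them only; others in the source may bear on it.

In an assay on isolated protein for inhibition of Amine oxidase [flavin-containing] B (Homo sapiens), read by fluorescence, with a stated time of 30 min (on this read-out lower numbers stand for stronger inhibition and higher numbers for weaker inhibition), compound 3 `COc1cc2c(cc1OC)C(=O)/C(=C/c1ccc(CN3CCCC3)c(O)c1)CO2` gives 722 nM, the lowest of the three numbers at hand. Compound 1 `COc1cc2c(cc1OC)C(=O)/C(=C/c1ccc(CN(C)C)c(O)c1)CO2` gives 882 nM, and compound 2 `CCN(CC)Cc1ccc(/C=C2\COc3cc(OC)c(OC)cc3C2=O)cc1O` gives 2430 nM. Compound 4 `COc1cc2c(cc1OC)C(=O)/C(=C/c1ccc(CN3CCCCC3)c(O)c1)CO2` differs from compound 3 by piperidin-1-yl in place of pyrrolidin-1-yl on a saturated chain carbon bound to an aromatic carbon. Going by the values given here, the steps that bear on this all exchange the amine on that same chain carbon: a 1.2-fold lower number from compound 1 to compound 3 (0.09 log units; within the scatter), a 3.4-fold lower number from compound 2 to compound 3 (0.53 log units; beyond the scatter), and a 2.8-fold higher number from compound 1 to compound 2 (0.44 log units; beyond the scatter). The two cyclic and smaller amines sit close together, while the larger acyclic amine in compound 2 reads higher, so for compound 4 a step of a 1.5-fold higher number from compound 3 to compound 4 (0.18 log units; within the scatter) is expected, toward a somewhat higher number but possibly within the scatter. Compound 4 is therefore estimated at 1100 nM, within a range from 450 nM to 2700 nM.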

Compound 4, half-maximal inhibitory concentration: 1740 nM
Compound 4: the middle estimate sits 1.6-fold (0.20 log units) below what was measured; measured number inside the range.
By their numbers in this assay, from the lowest: compounds 3, 1, 4 and 2 (each within the scatter of the next, the first and the last beyond it).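

In this assay, a ring on this chain carbon does not by itself keep the number low: piperidin-1-yl in place of pyrrolidin-1-yl gives a step beyond the scatter (a 2.4-fold higher number from compound 3 to compound 4 (0.38 log units; beyond the scatter)). Compound 4 instead lies within the scatter of both acyclic amines (a 1.4-fold lower number from compound 2 to compound 4 (0.15 log units; within the scatter); a 2.0-fold higher number from compound 1 to compound 4 (0.30 log units; within the scatter)), although those two differ from each other beyond it. No measurement shown here accounts for the step. On these data alone, whether a morpholin-4-yl ring or a primary amine on that carbon would read closer to compound 3 or to compound 4 remains open.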